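The compounds below may be only part of what the source reports. "The series", "measured", "known", "first", "only" and "open" are said of these compounds alone.

Measured compounds: compound 1 `CC(=O)N1c2ccccc2CCC1C(=O)Nc1ccccc1O` with 70700 nM; compound 2 `CCC(=O)N1c2ccccc2CCC1C(=O)Nc1ccccc1C(F)(F)F`; compound 3 `O=C(Nc1ccccc1C(F)(F)F)C1CCc2ccccc2N1C(=O)c1cccc(Cl)c1` with 729 nM.

In a functional assay on PC-3 cells (Homo sapiens) for cytotoxicity, read by sulforhodamine B assay, with a stated time of 72 h (on this read-out lower numbers stand for stronger inhibition of growth and higher numbers for weaker inhibition of growth), compound 1 gives 70700 nM. In this assay compound 2 reaches only the limit > 80000 nM, which is a limit of the assay and not a number. Compound 3, the one from which the step starts, gives 729 nM and stands lowest of the two numbers shown; compound 1 lies a good distance above it.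

Compound 4 `CC(=O)N1c2ccccc2CCC1C(=O)Nc1ccccc1C(F)(F)F` differs from compound 3 by methyl in place of 3-chlorophenyl on a carbonyl carbon. Within the data shown here, the one measured step that bears on this place is an at least 100-fold lower number from compound 2 to compound 3 (2.04 log units; beyond the scatter), where the 3-chlorophenyl carbonyl entered in place of a propionyl group. Compound 4 runs that step the other way, with an acetyl group in place of the 3-chlorophenyl carbonyl, and compound 1, itself an acetyl compound, sits far above compound 3. A large rise is therefore expected, of about a 100-fold higher number from compound 3 to compound 4 (2.01 log units; beyond the scatter). Compound 4 is estimated at 75000 nM, between 20000 nM and 300000 nM, with a real chance that only the limit is reported.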

Compound 4, concentration for 50% growth inhibition: > 80000 nM
Compound 4: only a limit was reported; the forecaster's own chance of this, stated with the estimate: 65%; middle value at least 1.0-fold (0.02 log units) away from the limit.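

In this assay the result is an at least 100-fold higher number from compound 3 to compound 4 (2.04 log units; beyond the scatter), so the loss of growth inhibition seen with ethyl returns with methyl, and the 3-chlorophenyl on the carbonyl carbon is what separates compound 3 from compound 2 and compound 4. With the acetyl kept, the other change, trifluoromethyl in place of hydroxy on an aromatic carbon, gives an at least 1.1-fold higher number from compound 1 to compound 4 (0.05 log units; that floor lies within the scatter), so no difference beyond the scatter can be claimed for that swap. The step between compound 2 and compound 4 cannot be read: the limit of > 80000 nM in this assay, at which 2 of the 4 values shown sit.

The compounds shown leave open whether the chlorine is needed, or whether a plain phenyl, a cyclohexyl or a longer chain on the carbonyl carbon would serve as well. As far as these compounds go, the trifluoromethyl and hydroxy pair appears only with acetyl, and how hydroxy or an amine behaves with the 3-chlorophenyl carbonyl stays open.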